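Swapping trifluoromethyl for methyl on a five-membered ring

The source may hold more compounds than are shown below. What is called first, only, known or untested is meant among the compounds shown, and "the series" means these compounds.

Of the compounds shown here, three have been tested in a functional assay on RD cells (Homo sapiens) for inhibition, read by luminescence and ATP content, with a stated time of 72 h (a lower number here means that less compound is tolerated, a higher number that more compound is tolerated), and a fourth awaits testing. Compound 1 `Nc1ccc(-c2ccc3ncc(-c4noc(C(F)(F)F)n4)cc3c2)cn1` and compound 3 `Cc1nc(-c2cnc3ccc(-c4ccc(N)nc4)cc3c2)no1` differ in one place: methyl in place of trifluoromethyl on an aromatic carbon. Compound 2 `CCCCc1ccc(-c2ccc3ncc(-c4noc(C(F)(F)F)n4)cc3c2)cc1` and compound 4 `CCCCc1ccc(-c2ccc3ncc(-c4noc(C)n4)cc3c2)cc1` differ in the same way, with the same surroundings: methyl in place of trifluoromethyl on an aromatic carbon. How the core of compound 2 differs from the core of compound 1 is not broken down here.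

In this assay compound 1 gives > 2500 nM, which is a limit of the assay rather than a number. Compound 3 gives > 7400 nM, also a limit. Compound 2 gives > 7400 nM, again a limit. The step that the two limits leave unreadable from compound 1 to compound 3 therefore cannot be read, because compound 1 sits at the limit of > 2500 nM in this assay, at which 1 of the 3 values shown sits, and compound 3 sits at the limit of > 7400 nM in this assay, at which 2 of the 3 values shown sit.

Because compound 2 sits at the limit of > 7400 nM in this assay, at which 2 of the 3 values shown sit, the step for the same change is expected to be about a step that the limit leaves unreadable from compound 2 to compound 4. Compound 4 is thus expected near 12000 nM, within 5000 nM to 40000 nM, and most likely reported only as a limit again.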

Compound 4, half-maximal cytotoxic concentration: > 2500 nM
Compound 4: no number, only a limit; the forecaster's own chance of this, stated with the estimate: 85%; the middle value does not contradict the limit.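

Compound 2 and compound 4 both give only limits of the assay in this assay, not numbers, so the step between them cannot be read. The compounds shown leave open how much, if at all, methyl in place of trifluoromethyl on this ring changes the concentration that is tolerated.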